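A Side Chain Replacement on Compound 3

The source may report more compounds than this note shows. Statements on the series, on what has been measured and on what is new or still open speak of the compounds shown alone.

In a functional assay on the whole organism with Rattus norvegicus as the target (on this read-out higher numbers stand for an effect only at larger amounts of compound and lower numbers for an effect already at smaller amounts), compound 1 `CCCn1c(=N)sc2cc(OC(F)(F)F)ccc21` gives 4.5 mg/kg and compound 3 `CN(C)CCn1c(=N)sc2cc(OC(F)(F)F)ccc21` gives 2.3 mg/kg. These two numbers lie within the scatter of each other. Compound 2 `N=c1sc2cc(OC(F)(F)F)ccc2n1CC(=O)O` reads > 10 mg/kg, which is a limit and not a number.

Compound 4 `CC[S+]([O-])CCn1c(=N)sc2cc(OC(F)(F)F)ccc21` departs from compound 3 as follows: a group of 4 heavy atoms (2 carbon, 1 oxygen, 1 sulfur; no ring) in place of a group of 3 heavy atoms (2 carbon, 1 nitrogen; no ring), on a saturated chain carbon, two bonds along the chain from an aromatic nitrogen.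

Among the measured compounds shown here, no measured step makes this exact replacement. The nearest evidence at this chain is a 2.0-fold lower number from compound 1 to compound 3 (0.29 log units; within the scatter), which stays within the scatter. Two larger steps involve the carboxy compound: an at least 2.2-fold higher number from compound 1 to compound 2 (0.34 log units; beyond the scatter) and an at least 4.3-fold lower number from compound 2 to compound 3 (0.63 log units; beyond the scatter). Compound 4 carries no carboxy group, so the smaller step is the better guide.

The expected result is a 1.5-fold higher number from compound 3 to compound 4 (0.18 log units; within the scatter), a change no larger than the scatter. For compound 4 the estimated value is 3.5 mg/kg, with an expected range of 1.3 mg/kg to 9 mg/kg.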

Compound 4, dose for half-maximal effect: 1.2 mg/kg
For compound 4 the middle estimate is 2.9-fold (0.46 log units) above the measured one; the measured number lies below the stated range.
By their numbers in this assay, from the lowest: compounds 4, 3 and 1 (each within the scatter of the next, the first and the last beyond it). At a limit, above all of these: compound 2.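

In this assay, the position on a saturated chain carbon, two bonds along the chain from an aromatic nitrogen, takes the new sulfur- and oxygen-bearing group in place of dimethylamino with a 1.9-fold lower number from compound 3 to compound 4 (0.28 log units; within the scatter). Measured against the plain chain of compound 1, this group gives a 3.8-fold lower number from compound 1 to compound 4 (0.57 log units; beyond the scatter), a step beyond the scatter, which dimethylamino did not reach. Compound 2 stands at a limit, so an at least 8.3-fold lower number from compound 2 to compound 4 (0.92 log units; beyond the scatter) is only a bound: the limit of > 10 mg/kg in this assay, at which 1 of the 4 values shown sits.

The compounds shown leave open whether the sulfur, its oxygen or the ethyl end carries this step. On these data alone, how a thioether, a sulfone or a longer chain would read at this position also remains open.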